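The source may report more compounds than this note shows. Statements on the series, on what has been measured and on what is new or still open speak of the compounds shown alone.

The measured compounds and their readings in a functional assay on MCF7 cells (Homo sapiens) for cytotoxicity, read by sulforhodamine B assay, with a stated time of 48 h; on this read-out higher numbers stand for weaker inhibition of growth and lower numbers for stronger inhibition of growth:
Compound 1 `COc1cc(/C(Cl)=C/C=C(\C#N)C(=O)c2c[nH]c3ccccc23)cc(OC)c1OC` gives 4000 nM.
Compound 2 `Cc1[nH]c2ccccc2c1C(=O)/C(C#N)=C/C=C(\Cl)c1ccc(Br)cc1` gives 73900 nM.
Compound 3 `COc1ccc(/C(Cl)=C/C=C(\C#N)C(=O)c2c[nH]c3ccccc23)cc1OC` gives 44200 nM.

Compound 1 has the lowest number of the three, and its steps to the other two are beyond the scatter, so it is the strongest inhibitor of growth in this set. Within the data shown here, the only single-point step among the measured compounds is an 11-fold higher number from compound 1 to compound 3 (1.04 log units; beyond the scatter), where one methoxy is taken away from the ring that carries three of them.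

Compound 4 `COc1ccc2[nH]cc(C(=O)/C(C#N)=C/C=C(\Cl)c3cc(OC)c(OC)c(OC)c3)c2c1` is not yet measured. It differs from compound 1 by methoxy in place of hydrogen on an aromatic carbon. This change is on the six-membered ring of the fused system of the shared core, whereas the step from compound 1 to compound 3 concerns the loss of a methoxy from the ring of three methoxy groups, so it does not bear on it directly. Among the measured compounds shown here, compound 2 carries a methyl on the fused system together with a different aryl group, so its value shows only that two changes at once gave a much higher number. For the measured compounds named here, no measured step tells how a methoxy on the fused system acts. In this assay the step for compound 4 is therefore expected to be small, no change at the digits printed from compound 1 to compound 4 (within the scatter), with no clear direction. Compound 4 is estimated at 4000 nM, in the range 1500 nM to 12000 nM.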

Compound 4, concentration for 50% growth inhibition: 39200 nM
Beside the measured number, compound 4's estimate is 9.8-fold (0.99 log units) below it; measured number above the stated range.
By their numbers in this assay, from the lowest: compound 1; then compounds 4, 3 and 2 (each within the scatter of the next).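

In this assay, the added methoxy gives a 9.8-fold higher number from compound 1 to compound 4 (0.99 log units; beyond the scatter), so the six-membered aromatic ring of the fused system is a place where a small substituent can clearly weaken growth inhibition, which no earlier single change could show. Among these compounds, the only earlier single change, an 11-fold higher number from compound 1 to compound 3 (1.04 log units; beyond the scatter), removed a methoxy from the ring of three methoxy groups, so compound 1 now has the lowest number against single changes on two different rings, one removing a methoxy and one adding a methoxy. Nothing available here explains why this added methoxy goes with a higher number.

With methoxy as the only substituent shown at this place, it remains open whether the loss of activity is particular to methoxy or would also come with a fluorine atom, a hydroxyl or an amine. It also remains open whether a methoxy on another carbon of this same ring would give a similar number, since only this one placement can be read from the compounds shown.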